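Swapping 3-chlorophenyl for thiophen-2-yl in compound 3

This account rests on a few compounds, and the source may have more. Where it says the series, first, only, none or still open, it means among the compounds named here.

Of the compounds shown here, three sharing one core have been tested in a functional assay on ECa-109 cells (Homo sapiens) for antiproliferative activity, read by MTT assay, with a stated time of 72 h; on this read-out lower numbers stand for stronger inhibition and higher numbers for weaker inhibition. Compound 1 (`CCCSc1nc(N/N=C/c2ccc(C)cc2)c2nnn(Cc3ccccc3)c2n1`) gives > 64000 nM as a limit of the assay and not a number. Compound 2 (`CCCSc1nc(N/N=C/c2ccc(Cl)cc2)c2nnn(Cc3ccccc3)c2n1`) gives > 64000 nM as a limit too. Compound 3 (`CCCSc1nc(N/N=C/c2cccc(Cl)c2)c2nnn(Cc3ccccc3)c2n1`) likewise gives > 64000 nM as a limit. Compound 3 therefore stands at the limit of > 64000 nM in this assay, at which 3 of the 3 values shown sit, and cannot be ranked against the other two.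

Compound 4 (`CCCSc1nc(N/N=C/c2cccs2)c2nnn(Cc3ccccc3)c2n1`) carries thiophen-2-yl in place of 3-chlorophenyl on a carbon with a double bond to nitrogen. Two measured changes touch this same place. They are a step that the two limits leave unreadable from compound 1 to compound 3 and a step that the two limits leave unreadable from compound 2 to compound 3 and neither gives a size to build on. With only the limit of > 64000 nM in this assay, at which 3 of the 3 values shown sit, as a guide, no step beyond the scatter is expected in this assay and no direction can be favoured. The expected step is a number no higher from compound 3 to compound 4 (the limit leaves the size open) as an estimate. Compound 4 is expected to read about 64000 nM with an estimated range of 25000 nM to 128000 nM and may well return only a limit again.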

Compound 4, half-maximal inhibitory concentration: > 64000 nM
Compound 4 gave a limit, no number; the forecaster's own chance of this, stated with the estimate: 75%; the middle value lies on the limit itself.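

Compound 4 gives only a limit in this assay, as do compound 1, compound 2 and compound 3, so no step among these four compounds can be read: the limit of > 64000 nM in this assay, at which 4 of the 4 values shown sit.

The compounds shown leave open how these four rank against one another, and whether any group at this place on the shared core would give a measurable number.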